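From 1,2-dihydroxyethyl to carboxy on the shared core

A few compounds are considered here, and "the series" means these few. Any claim that something is new, unique, unknown or untested is made for them only; others in the source may bear on it.

compound 1 `CNC(=O)C[C@@H]1C[C@@H](c2ccc(Cl)c(Cl)c2)[C@H](NC(=O)c2cc(-c3c(Cl)cnn3C)c(Cl)o2)CN1` gives 40 nM
compound 2 `Cn1ncc(Cl)c1-c1cc(C(=O)N[C@@H]2CN[C@H](CC(O)CO)C[C@H]2c2ccc(Cl)c(Cl)c2)oc1Cl` gives 70 nM
compound 3 `CC(=O)NCC[C@@H]1C[C@@H](c2ccc(F)c(F)c2)[C@H](NC(=O)c2cc(-c3c(Cl)cnn3C)c(Cl)o2)CN1` gives 130 nM

All three compounds were measured in a functional assay on LNCaP cells (Homo sapiens) for antiproliferative activity; a lower number here means a stronger inhibitor, a higher number a weaker inhibitor. Compound 2 stands in the middle of the three numbers, within the scatter of both compound 1 and compound 3. Still unmeasured, compound 4 `Cn1ncc(Cl)c1-c1cc(C(=O)N[C@@H]2CN[C@H](CC(=O)O)C[C@H]2c2ccc(Cl)c(Cl)c2)oc1Cl` carries carboxy in place of 1,2-dihydroxyethyl on a saturated chain carbon bound to a saturated ring carbon. For the measured compounds named here, one measured step bears on this place: a 1.8-fold higher number from compound 1 to compound 2 (0.24 log units; within the scatter), with 1,2-dihydroxyethyl in place of methylcarbamoyl, and it stays within the scatter. Going by the values given here, compound 3 differs from compound 2 in more than one place and gives no clean step. Among the compounds with values here, no measured compound carries carboxy, so this single step is only a loose guide. A small move towards a higher number in this assay is expected, not clearly beyond the scatter. The expected change is a 1.7-fold higher number from compound 2 to compound 4 (0.23 log units; within the scatter), and it remains an estimate. Compound 4 is estimated at 120 nM, with an expected range from 40 nM to 400 nM.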

Compound 4, half-maximal inhibitory concentration: 640 nM
Estimate against measurement, compound 4: 5.3-fold (0.73 log units) below, outside the stated range (above it).
By their numbers in this assay, from the lowest: compounds 1, 2 and 3 (each within the scatter of the next, the first and the last beyond it); then compound 4.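

In this assay, the place on a saturated chain carbon bound to a saturated ring carbon turns out to be sensitive to the group it carries: carboxy in place of 1,2-dihydroxyethyl gives (a 9.1-fold higher number from compound 2 to compound 4 (0.96 log units; beyond the scatter)), whereas the earlier change from methylcarbamoyl to 1,2-dihydroxyethyl (a 1.8-fold higher number from compound 1 to compound 2 (0.24 log units; within the scatter)) stayed within the scatter. Hydroxy in place of methylamino on a carbonyl carbon gives a larger step (a 16-fold higher number from compound 1 to compound 4 (1.20 log units; beyond the scatter)), so that a small edit to the carbonyl group separates compound 1 clearly from compound 4. Among these compounds, then, the neutral amide and the diol sit close together and carboxy alone falls away. Nothing available here accounts for this loss. The compounds shown leave open how a methyl ester, a primary amide or a primary amine would behave on this same carbon. They also leave open whether a longer chain ending in carboxy would give a number closer to that of compound 2.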